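A few compounds are considered here, and "the series" means these few. Any claim that something is new, unique, unknown or untested is made for them only; others in the source may bear on it.

In a functional assay on H4 cells for agonist activity at growth hormone secretagogue receptor type 1 (Homo sapiens), read by FLIPR (a lower number here means that less compound is needed, a higher number that more compound is needed for the effect), compound 1 `CN(c1ccccc1CCCn1nnnc1[C@@H](COCc1ccccc1)NC(=O)C(C)(C)N)S(C)(=O)=O` gives 14 nM. Compound 2 `CC(C)(N)C(=O)N[C@H](COCc1ccccc1)c1nnn(Cc2ccc(NS(C)(=O)=O)cc2)n1` gives 986 nM in this assay, the higher of the two numbers; the gap to compound 1 lies beyond the scatter, but the two structures differ in several places at once, so no single change can be read from that pair. Compound 3 `CC(C)(N)C(=O)N[C@H](COCc1ccccc1)c1nnn(Cc2ccccc2NS(C)(=O)=O)n1` has not yet been measured in this assay. It differs from compound 2 in one place: 2-(methanesulfonamido)phenyl in place of 4-(methanesulfonamido)phenyl on a saturated chain carbon bound to an aromatic nitrogen. For the measured compounds named here, no matched step for this change exists among the measured compounds, and compound 1 is not a matched partner for either of them. On that thin basis, the step from compound 2 to compound 3 is expected to be a modest lowering of the number, a 2.5-fold lower number from compound 2 to compound 3 (0.39 log units; beyond the scatter), with wide uncertainty in both directions. For compound 3 the estimate in this assay is 400 nM, in a range from 80 nM to 2000 nM.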

Compound 3, half-maximal effective concentration: 426 nM
Compound 3: the middle estimate sits 1.1-fold (0.03 log units) below what was measured; the range from low to high includes it.
By their numbers in this assay, from the lowest: compound 1; then compound 3; then compound 2.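

In this assay, for the compounds shown here, 2-(methanesulfonamido)phenyl in place of 4-(methanesulfonamido)phenyl on a saturated chain carbon bound to an aromatic nitrogen gives a 2.3-fold lower number from compound 2 to compound 3 (0.36 log units; beyond the scatter) and is the first matched step. The two groups have the same atoms and the same counts, so the way they are joined is enough to move the number beyond the scatter at this position, with 2-(methanesulfonamido)phenyl the better of the two. No measurement here explains the size or direction of this step.

Still open, as far as these compounds go, is whether an amine or a carboxylic acid in place of the methanesulfonamido group would keep, lose or extend this step. It is also unknown whether the same change would hold on the longer chain of compound 1.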